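Ethoxy in Place of Propylsulfanyl on the Shared Core

The source may hold more compounds than are shown below. What is called first, only, known or untested is meant among the compounds shown, and "the series" means these compounds.

Compound 1, `CSc1nnc(Cc2ccccc2Oc2ccccc2)[nH]1`, gives 147% in a functional assay on the whole organism (strain NMRI) with Mus musculus as the target, with a stated time of 60 min, at a dose of 20 mg/kg by the intraperitoneal route; on this read-out lower numbers stand for a weaker effect and higher numbers for a stronger effect at the one dose given.
Compound 2, `CCCSc1nnc(Cc2ccccc2Oc2ccccc2)[nH]1`, gives 158% in this assay.
Compound 3, `CSc1nnc(Cc2ccc(Cl)cc2Oc2ccccc2Cl)[nH]1`, gives 170% in this assay.

Among these three numbers compound 2 stands second highest: compound 1 sits lower and compound 3 sits higher, both beyond the scatter. Compound 4, `CCOc1nnc(Cc2ccccc2Oc2ccccc2)[nH]1`, differs from compound 2 by ethoxy in place of propylsulfanyl on an aromatic carbon. Among the compounds with values here, the only measured step on this part of the core is a number 11 percentage points higher from compound 1 to compound 2 (beyond the scatter), a modest gain from a longer chain on sulfur; no measured step exchanges sulfur for oxygen, so that side of the change is untested. The move to ethoxy on compound 4 is expected to give back part of that gain, a step of a number 8 percentage points lower from compound 2 to compound 4 (within the scatter). Compound 4 is therefore estimated at 150%, in a range from 130% to 170%.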

Compound 4, a percentage reported as activity, at one dose (the size of the read-out at that dose, not a potency): 144%
Beside the measured number, compound 4's estimate is 6 percentage points above it; low and high end bracket the measured number.
By their numbers in this assay, from the lowest: compounds 4 and 1 (each within the scatter of the next); then compound 2; then compound 3.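

Within the data shown here, the aromatic carbon between two ring nitrogen atoms now carries an oxygen-linked chain for the first time, and this assay shows a number 14 percentage points lower from compound 2 to compound 4 (beyond the scatter) together with a number 3 percentage points lower from compound 1 to compound 4 (within the scatter) on the same core. Ethoxy therefore does not hold the gain seen with propylsulfanyl and reads level with methylsulfanyl. No evidence on hand accounts for this difference.

From the compounds shown here alone, what propoxy or methoxy would give at this place stays open, so the oxygen and the chain length cannot be separated. Going by these compounds, an amine here is equally open.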